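Plasma stability along a flexible linker chain

A few compounds are considered here, and "the series" means these few. Any claim that something is new, unique, unknown or untested is made for them only; others in the source may bear on it.

Compound 3: `CCCC(=O)NCCCCCC(=O)N[C@H](C(=O)N1C[C@H](O)C[C@H]1C(=O)NCc1ccc(-c2scnc2C)cc1)C(C)(C)C`, 83%
Compound 1: `Cc1ncsc1-c1ccc(CNC(=O)[C@@H]2C[C@@H](O)CN2C(=O)[C@@H](NC(=O)CCCCCOC(=O)CC(c2ccccc2)c2ccccc2)C(C)(C)C)cc1`, 58%
Compound 2: `CCCCOc1ccc(-c2ccc(C(=O)OCCCCCC(=O)N[C@H](C(=O)N3C[C@H](O)C[C@H]3C(=O)NCc3ccc(-c4scnc4C)cc3)C(C)(C)C)cc2)cc1`, 119%

In an ADME assay on a cell-free system (plasma, Homo sapiens) for metabolic stability, with a stated time of 90 min (on this read-out higher numbers stand for a more stable compound and lower numbers for a less stable compound), compound 3 gives 83%, the second highest of the three numbers. Its nearest neighbour is compound 1, which in this assay gives 58%, a value beyond the scatter below it. Compound 2 stands furthest away with 119%, also beyond the scatter.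

The step leads from compound 3 to compound 4, `COCC(=O)OCCCCCC(=O)N[C@H](C(=O)N1C[C@H](O)C[C@H]1C(=O)NCc1ccc(-c2scnc2C)cc1)C(C)(C)C`, which has not yet been measured in this assay. The change between the two is ((methoxymethyl)carbonyl)oxy in place of (propylcarbonyl)amino on a saturated chain carbon, five bonds along the chain from a carbonyl carbon. The chain and the shared core are otherwise the same.

Among the compounds with values here, no measured pair differs in exactly this way, so the expectation rests on compound 1 and compound 3 alone. The step from compound 3 to compound 4 is estimated as a number 23 percentage points lower from compound 3 to compound 4 (beyond the scatter), a drop beyond the scatter, because compound 1 gives 58%. Compound 4 is therefore expected to reach about 60%, with a range from 35% to 85%.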

Compound 4, percent of the compound remaining: 1%
Compound 4: middle estimate off by 59 percentage points, on the high side, and the stated range ends above it.
By their numbers in this assay, from the lowest: compound 4; then compound 1; then compound 3; then compound 2.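

In this assay, within the data shown here, the exchange of (propylcarbonyl)amino for ((methoxymethyl)carbonyl)oxy on a saturated chain carbon, five bonds along the chain from a carbonyl carbon, gives a step of a number 82 percentage points lower from compound 3 to compound 4 (beyond the scatter) and thus the first single-place comparison at this position. Both groups have the same number of heavy atoms, no ring and one double bond outside aromatic rings, so these shared counts do not keep the read-out in place here. Nothing available explains the size of this drop.

The compounds shown leave open whether the oxygen link to the chain or the methoxymethyl end accounts for the step, since no pair separates the two. As far as these compounds go, how an amine or a carboxylic acid at this chain carbon would read out in this assay also remains open.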